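Swapping the Anilino Aryl Group at the Assay Ceiling

A few compounds are considered here, and "the series" means these few. Any claim that something is new, unique, unknown or untested is made for them only; others in the source may bear on it.

Of the compounds shown here, two have so far been tested in a functional assay on PC-3 cells (Homo sapiens) for inhibition, read by MTT assay, with a stated time of 72 h; a higher number here means a weaker inhibitor, a lower number a stronger inhibitor. Compound 1 `C=CC(=O)Nc1cccc(NC(=O)CSc2nc(Nc3cccc([N+](=O)[O-])c3)c3ccccc3n2)c1` carries a 3-nitrophenyl on the anilino nitrogen, and in this assay compound 1 gives 46300 nM. Compound 2 `C=CC(=O)Nc1cccc(NC(=O)CSc2nc(Nc3cc(OC)c(OC)c(OC)c3)c3ccccc3n2)c1` carries a 3,4,5-trimethoxyphenyl at the same nitrogen; for compound 2 this assay reports only a limit, > 50000 nM. Going by the values given here, the single measured step, an at least 1.0-fold higher number from compound 1 to compound 2 (0.03 log units; that floor lies within the scatter), therefore sits at the ceiling of the method, and the limit of > 50000 nM in this assay, at which 1 of the 2 values shown sits, marks where compound 2 stands. Compound 3 `C=CC(=O)Nc1cccc(NC(=O)CSc2nc(Nc3ccc(F)c(Cl)c3)c3ccccc3n2)c1` is the next variation: 3-chloro-4-fluorophenyl in place of 3,4,5-trimethoxyphenyl on a nitrogen on an aromatic ring. Among the compounds with values here, no measured step addresses this particular exchange, and the one step that exists went nowhere beyond the scatter, so the expectation for compound 3 rests only on both measured compounds lying at or near the limit. The step from compound 2 to compound 3 is expected to be an at least 1.1-fold lower number from compound 2 to compound 3 (0.04 log units; that floor lies within the scatter). Compound 3 is accordingly estimated at 45000 nM, within a range from 15000 nM to 100000 nM.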

Compound 3, half-maximal inhibitory concentration: > 50000 nM
Compound 3: a limit, no number; the forecaster's own chance of this, stated with the estimate: 55%; middle value at least 1.1-fold (0.04 log units) from the limit.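

In this assay compound 3 also gives only a limit, > 50000 nM, and the step from compound 2 to compound 3 cannot be read, as both ends are limits. Placing 3-chloro-4-fluorophenyl in place of 3-nitrophenyl on this nitrogen gives an at least 1.0-fold higher number from compound 1 to compound 3 (0.03 log units; that floor lies within the scatter), so this exchange shows no readable change either. With a halogen-bearing ring now added to the nitro and trimethoxy rings, all three aryl groups on this nitrogen read at or close to the ceiling of the method: the limit of > 50000 nM in this assay, at which 2 of the 3 values shown sit.

As far as these compounds go, what stays open is whether any group on this nitrogen can bring the number clearly under that limit, for instance an unsubstituted phenyl, a pyridine ring or a 3-ethynylphenyl. Also open, from the compounds shown here alone, is whether a change elsewhere, such as a propanamide in place of the acrylamide, would make differences at this position readable at all.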